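The source may report more compounds than this note shows. Statements on the series, on what has been measured and on what is new or still open speak of the compounds shown alone.

Measured in a functional assay on HT-29 cells (Homo sapiens) for cytotoxicity, read by MTT assay, with a stated time of 72 h; on this read-out lower numbers stand for stronger inhibition and higher numbers for weaker inhibition:
compound 1, `COc1cc2c(Oc3ccc(NC(=O)c4cn(-c5ccccc5C)nn4)cc3F)ccnc2cc1OCCCN1CCCC1`, gives 1200 nM
compound 2, `COc1cc2c(Oc3ccc(NC(=O)c4cn(-c5c(C)cccc5C)nn4)cc3F)ccnc2cc1OCCCN1CCCC1`, gives 2240 nM
compound 3, `COc1cc2c(Oc3ccc(NC(=O)c4cn(-c5ccccc5F)nn4)cc3F)ccnc2cc1OCCCN1CCCCC1`, gives 290 nM

Compound 3 stands lowest of these three numbers in this assay. Its distance to compound 1 and to compound 2 is in each case beyond the scatter, so compound 3 is the most potent of the three on this read-out. Compound 4, `COc1cc2c(Oc3ccc(NC(=O)c4cn(-c5ccc(F)c(F)c5)nn4)cc3F)ccnc2cc1OCCCN1CCCCC1`, differs from compound 3 in one place: 3,4-difluorophenyl in place of 2-fluorophenyl on an aromatic nitrogen. Among the compounds with values here, only one measured step touches this same aromatic ring, and it is of a different kind: a 1.9-fold higher number from compound 1 to compound 2 (0.27 log units; within the scatter). That step added a methyl rather than moving or adding a fluorine, and it stayed within the scatter. Within the data shown here, no measured pair shows what shifting fluorine from one spot on this ring to two other spots does, nor what the shared core of compound 3, with its piperidine-bearing chain, does when the ring is changed. On this thin ground the expected step from compound 3 to compound 4 is small, and a modest rise in the number is as likely as none: a 1.4-fold higher number from compound 3 to compound 4 (0.14 log units; within the scatter). Compound 4 is therefore estimated at 400 nM in this assay, with a range from 150 nM to 1100 nM.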

Compound 4, half-maximal inhibitory concentration: 210 nM
Compound 4: middle estimate off by 1.9-fold (0.28 log units), on the high side, within the range that was stated.
By their numbers in this assay, from the lowest: compounds 4 and 3 (each within the scatter of the next); then compounds 1 and 2 (each within the scatter of the next).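

In this assay, putting 3,4-difluorophenyl in place of 2-fluorophenyl on the aromatic nitrogen of the five-membered ring gives a 1.4-fold lower number from compound 3 to compound 4 (0.14 log units; within the scatter), so the two compounds cannot be told apart on this read-out. Within the data shown here, the only earlier step at this ring, a 1.9-fold higher number from compound 1 to compound 2 (0.27 log units; within the scatter), added a methyl group on a different chain, whereas this new step shows that, with the piperidine-bearing chain in place, the fluorine pattern on the ring can be exchanged with no difference beyond the scatter: the fluorine of 2-fluorophenyl is not needed to keep the number in this range when 3,4-difluorophenyl takes its place. Nothing shown here bears on why these two groups give such similar numbers.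

As far as these compounds go, it remains open whether this tolerance extends beyond fluorine and methyl, for instance to a plain phenyl or to a phenyl ring carrying an amine or a carboxylic acid. From the compounds shown here alone, it is also open whether fluorine changes on this ring would read the same way with the chain of compound 1, since compound 1 and compound 3 differ in more than one place.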